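Quinoline Swap on a Chloro Core: Expected Cytotoxicity

The source may report more compounds than this note shows. Statements on the series, on what has been measured and on what is new or still open speak of the compounds shown alone.

Compound 1 `COc1ccc(-c2nc3ccccn3c2C(=O)/C=C\Nc2cnc3ccccc3c2)cc1` gives 1050 nM in a functional assay on A549 cells (Homo sapiens) for cytotoxicity, read by MTT assay, with a stated time of 48 h; a higher number here means a weaker inhibitor, a lower number a stronger inhibitor. Compound 2 `COc1ccc(-c2nc3ccccn3c2C(=O)/C=C\Nc2ccc3ncccc3c2)cc1` carries quinolin-6-yl in place of quinolin-3-yl on an amine nitrogen and gives 1210 nM in this assay; the step is a 1.2-fold higher number from compound 1 to compound 2 (0.06 log units; within the scatter). Compound 3 `O=C(/C=C\Nc1cnc2ccccc2c1)c1c(-c2ccc(Cl)cc2)nc2ccccn12` differs from compound 1 by chloro in place of methoxy on an aromatic carbon; in this assay compound 3 gives 2880 nM, a step of a 2.7-fold higher number from compound 1 to compound 3 (0.44 log units; beyond the scatter). Compound 4 `O=C(/C=C\Nc1ccc2ncccc2c1)c1c(-c2ccc(Cl)cc2)nc2ccccn12` is not yet measured. It differs from compound 3 by quinolin-6-yl in place of quinolin-3-yl on an amine nitrogen, the same change that separates compound 1 and compound 2, made here on the core of compound 3 rather than that of compound 1. Because that earlier change gave a 1.2-fold higher number from compound 1 to compound 2 (0.06 log units; within the scatter), a similarly small step is expected for compound 4, namely a 1.2-fold higher number from compound 3 to compound 4 (0.07 log units; within the scatter). Compound 4 is therefore estimated at 3400 nM, within 1700 nM to 7000 nM, an expectation resting on one prior example only.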

Compound 4, half-maximal inhibitory concentration: 13000 nM
Compound 4: middle estimate off by 3.8-fold (0.58 log units), on the low side; the measured number lies above the stated range.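

In this assay, quinolin-6-yl in place of quinolin-3-yl on the amine nitrogen did not carry over unchanged from the core of compound 1 to the core of compound 3, giving a 4.5-fold higher number from compound 3 to compound 4 (0.65 log units; beyond the scatter): the same change on two cores in this assay, a 1.2-fold higher number (0.06 log units; within the scatter) from compound 1 to compound 2 and a 4.5-fold higher number (0.65 log units; beyond the scatter) from compound 3 to compound 4, 3.9-fold (0.59 log units) apart, beyond the scatter of two such steps Seen from the other side, chloro in place of methoxy weighs more heavily when quinolin-6-yl is present, with an 11-fold higher number from compound 2 to compound 4 (1.03 log units; beyond the scatter): the same change on two cores in this assay, a 2.7-fold higher number (0.44 log units; beyond the scatter) from compound 1 to compound 3 and an 11-fold higher number (1.03 log units; beyond the scatter) from compound 2 to compound 4, 3.9-fold (0.59 log units) apart, beyond the scatter of two such steps So, in these four compounds, the size of each change depends on the other, but this single pair of cores does not show why or whether the same holds on any other core.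

The compounds shown leave open whether fluoro or methyl in place of chloro would follow chloro or methoxy. They also leave open how a plain phenyl on the amine nitrogen would compare with either quinoline.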